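The compounds below may be only part of what the source reports. "The series", "measured", "known", "first", "only" and "open" are said of these compounds alone.

Working notes on the series. Compound 1 `c1cncc(CNCCCCN(C[C@H]2Cc3ccccc3CN2)[C@H]2CCCc3cccnc32)c1` is a limit in a functional assay on cells for agonist activity at C-X-C chemokine receptor type 4 (Homo sapiens), read by fluorescence and calcium flux, with a stated time of 90 s (a lower number here means that less compound is needed, a higher number that more compound is needed for the effect), reported as > 30000 nM. Compound 2 `c1ccc2c(c1)CN[C@@H](CN(CCCCNC1CCCCC1)[C@H]1CCCc3cccnc31)C2` is likewise only a limit in this assay, at > 30000 nM. Compound 3 `C(=C/CN(C[C@H]1Cc2ccccc2CN1)[C@H]1CCCc2cccnc21)\CNC1CCOCC1` also gives a limit in this assay, > 30000 nM. All three sit at the limit of > 30000 nM in this assay, at which 3 of the 3 values shown sit, so compound 3 stands at the limit and no better than either of the others. The steps from compound 1 to compound 2 a step that the two limits leave unreadable from compound 1 to compound 2, from compound 1 to compound 3 a step that the two limits leave unreadable from compound 1 to compound 3 and from compound 2 to compound 3 a step that the two limits leave unreadable from compound 2 to compound 3 are all unreadable. Compound 4 `C(=C/CN(C[C@H]1Cc2ccccc2CN1)[C@H]1CCCc2cccnc21)\CNCc1ccccn1` differs from compound 3 by (pyridin-2-yl)methyl in place of oxan-4-yl on an amine nitrogen. Nothing measured resolves this change, so no step beyond the scatter is expected; the expected step from compound 3 to compound 4 is a step that the limit leaves unreadable from compound 3 to compound 4. Compound 4 is therefore estimated at 40000 nM, with a range from 8000 nM to 200000 nM, most likely reported again as a limit.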

Compound 4, half-maximal effective concentration: > 30000 nM
Compound 4 gave a limit, no number; the forecaster's own chance of this, stated with the estimate: 85%; the middle value is on the limit's open side.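

Compound 4 gives only a limit, > 30000 nM, so its steps from compound 1, compound 2 and compound 3 cannot be read. The compounds shown leave open which change to the shared core, if any, gives a number rather than a limit in this assay: the limit of > 30000 nM in this assay, at which 4 of the 4 values shown sit.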